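A few compounds are considered here, and "the series" means these few. Any claim that something is new, unique, unknown or untested is made for them only; others in the source may bear on it.

Compound 1 `Cc1cc(NC(=O)Nc2ccccc2F)c2ccccc2n1` and compound 2 `COC(=O)c1ccc(NC(=O)Nc2cc(C)nc3ccccc23)cc1` share one core. In an ADME assay on BJ cells (Homo sapiens) for cytotoxicity, with a stated time of 72 h (a lower number here means that less compound is needed, a higher number that more compound is needed for the effect), compound 1 reaches only the limit of the assay, > 25000 nM. In this assay, among the compounds with values here, compound 2 gives 21000 nM, the single number among the values at hand. The value of compound 1 is a limit of the assay, (the limit of > 25000 nM in this assay, at which 1 of the 2 values shown sits). Compound 3 `CCc1ccc(NC(=O)Nc2cc(C)nc3ccccc23)cc1` differs from compound 2 in one place: ethyl in place of methoxycarbonyl on an aromatic carbon. Within the data shown here, no measured pair shows the effect of such a change, so the step from compound 2 to compound 3 is expected to stay within the scatter, a 1.2-fold lower number from compound 2 to compound 3 (0.07 log units; within the scatter). For compound 3 in this assay the estimate is 18000 nM, from 7000 nM to 25000 nM.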

Compound 3, half-maximal effective concentration: > 25000 nM
Compound 3: only a limit was reported; the forecaster's own chance of this, stated with the estimate: 40%; at least 1.3-fold (0.14 log units) between middle value and limit.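

In this assay, within the data shown here, ethyl in place of methoxycarbonyl on this aromatic carbon, para to a large group, gives the first step that can be read: an at least 1.1-fold higher number from compound 2 to compound 3 (0.07 log units; that floor lies within the scatter). So on this carbon, the swap to the smaller ethyl does not bring the number down, although the true size of the step remains unknown. Only a floor can be read, and the value of compound 3 is a limit: the limit of > 25000 nM in this assay, at which 2 of the 3 values shown sit.

The compounds shown leave open how an amine, a carboxylic acid or a longer chain would read on this carbon. They also leave open how far compound 3 lies past its limit.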